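Aryl group on the amide nitrogen: compound 2 to compound 4

This account rests on a few compounds, and the source may have more. Where it says the series, first, only, none or still open, it means among the compounds named here.

Of the compounds shown here, three on the shared core have been tested in a functional assay on A549 cells (Homo sapiens) for cytotoxicity, read by MTT assay, with a stated time of 72 h; a lower number here means a stronger inhibitor, a higher number a weaker inhibitor. Compound 1 `O=C(CN1CCN(c2nnc(Cc3ccccc3)c3ccccc23)CC1)Nc1c(F)cccc1F` gives 84500 nM. Compound 3 `Cc1ccc(F)cc1NC(=O)CN1CCN(c2nnc(Cc3ccncc3)c3ccccc23)CC1` gives 38900 nM. Compound 2 `Cc1ccc(F)cc1NC(=O)CN1CCN(c2nnc(Cc3ccccc3)c3ccccc23)CC1` has no single number and is reported as "not active" (no number reported). Among the compounds with values here, it therefore cannot be placed numerically against the other two, and no step can be calculated from it.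

Compound 4 `O=C(CN1CCN(c2nnc(Cc3ccccc3)c3ccccc23)CC1)Nc1ccc(Br)cc1` is the next compound for this assay. Its structural change is 4-bromophenyl in place of 5-fluoro-2-methylphenyl on an amide-type nitrogen. In words, 4-bromophenyl stands in place of 5-fluoro-2-methylphenyl on an amide-type nitrogen, and the rest of the molecule is unchanged.

Within the data shown here, no measured step sizes this change, and the small set offers no tested example of this replacement. The expectation is a modest move in the direction of stronger inhibition from compound 2, enough to yield a measurable value, though another result without a number remains quite possible. Any number is expected to fall in the same high range as compound 1 at 84500 nM, with no clear gain beyond it. Compound 4 is estimated at 60000 nM, with an expected range of 20000 nM to 150000 nM.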

Compound 4, half-maximal inhibitory concentration: 2000 nM
The estimate for compound 4 lay 30-fold (1.48 log units) above the measured number; measured number outside the range, below it.
By their numbers in this assay, from the lowest: compound 4; then compound 3; then compound 1.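

In this assay, the aryl group on the amide-type nitrogen proves to be a position of large effect on the shared core: 4-bromophenyl in place of 2,6-difluorophenyl gives a 42-fold lower number from compound 1 to compound 4 (1.63 log units; beyond the scatter). Compound 2 is reported as "not active" while compound 4 gives 2000 nM, so 4-bromophenyl in place of 5-fluoro-2-methylphenyl separates a compound without a number from one with a number, but this step cannot be read as a size. Nothing shown here accounts for the difference between these aryl groups.

The compounds shown leave open whether the lower number belongs to the bromine itself or to the aryl group as a whole; an unsubstituted phenyl, or a chlorine or methyl in place of the bromine in 4-bromophenyl, would help to separate the two. Also open, going by these compounds, is whether 4-bromophenyl on the amide-type nitrogen would keep its effect alongside the other group that compound 3 carries on the core, since compound 3 and compound 4 differ in more than one place.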